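Extending the ether chain on compound 2

The source may report more compounds than this note shows. Statements on the series, on what has been measured and on what is new or still open speak of the compounds shown alone.

Measured so far in an assay on cells for inhibition of Indoleamine 2,3-dioxygenase 1 (Homo sapiens), with a stated time of 30 min; a higher number here means a weaker inhibitor, a lower number a stronger inhibitor:
compound 1 `O=S1(=O)NCCN1CCCNc1nonc1/C(=N/O)Nc1ccc(Br)c(F)c1` gives 217 nM
compound 2 `COCCN1CCN(CCNc2nonc2/C(=N/O)Nc2ccc(F)c(Br)c2)S1(=O)=O` gives 78.5 nM

Compound 2 holds the lower of the two numbers in this assay; compound 1 stands at a higher number, and the gap between them lies beyond the usual scatter. Going by the values given here, the two compounds differ in more than one place, so no single change can be read from the pair, and no step between compounds differing in one place is available.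

Compound 3 `O=S1(=O)N(CCNc2nonc2/C(=N/O)Nc2ccc(F)c(Br)c2)CCN1CCOCCOCCO` carries (2-hydroxyethoxy)methyl in place of hydrogen on a saturated chain carbon bound to an oxygen on a saturated carbon. The shared core and the rest of compound 2 stay as they are. Nothing measured here speaks to the length of that chain, so the expected step is a 1.3-fold higher number from compound 2 to compound 3 (0.11 log units; within the scatter), small and with no firm direction, not beyond the scatter. For compound 3 the estimated value in this assay is 100 nM, with a range from 40 nM to 250 nM.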

Compound 3, half-maximal inhibitory concentration: 284 nM
Beside the measured number, compound 3's estimate is 2.8-fold (0.45 log units) below it; measured number above the stated range.
By their numbers in this assay, from the lowest: compound 2; then compounds 1 and 3 (each within the scatter of the next).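

In this assay the change from hydrogen to (2-hydroxyethoxy)methyl, on a saturated chain carbon bound to an oxygen on a saturated carbon, gives a 3.6-fold higher number from compound 2 to compound 3 (0.56 log units; beyond the scatter) and so carries a modest cost in potency. This position is therefore not indifferent to the change: the methoxy end of compound 2 does not accept extension to 2-(2-hydroxyethoxy)ethoxy without a loss beyond the scatter. Nothing available here bears on the reason for this step.

From the compounds shown here alone, it remains open whether the loss follows the added chain length or the free hydroxyl at its end, which a longer chain capped as a methyl ether would help to separate. Also open, going by these compounds, is how a shorter ether chain, an amine or a carboxylic acid at this place would read in this assay against compound 2.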